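Urea Side-Chain Chlorine Position on Two Related Cores

The source may report more compounds than this note shows. Statements on the series, on what has been measured and on what is new or still open speak of the compounds shown alone.

The measured compounds are:
compound 1, `CCN(CC)CCNc1nc(-c2ccc(NC(=O)Nc3ccc(Cl)cc3)cc2)nc2c(Cl)c(Cl)sc12`, 890 nM;
compound 2, `CCN(CC)CCNc1nc(-c2ccc(NC(=O)Nc3ccc(Cl)cc3)cc2)nc2ccsc12`, 370 nM;
compound 3, `CCN(CC)CCNc1nc(-c2ccc(NC(=O)Nc3ccccc3Cl)cc2)nc2c(Cl)c(Cl)sc12`, 1130 nM.

All three were tested in a functional assay on MKN-45 cells (Homo sapiens) for cytotoxicity, read by MTT assay, with a stated time of 72 h; on this read-out lower numbers stand for stronger inhibition and higher numbers for weaker inhibition. Compound 2 gives the lowest of the three numbers; its distance to compound 1 and to compound 3 is beyond the usual scatter in each case. Compound 1 and compound 3 share one core, and compound 2 carries a different one; the difference between the two cores is not broken down here.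

Within the core of compound 1, a single change leads to compound 3: 2-chlorophenyl in place of 4-chlorophenyl on an amide-type nitrogen. The step it made, a 1.3-fold higher number from compound 1 to compound 3 (0.10 log units; within the scatter), is small enough to sit within the scatter, so on this core the two chlorophenyl arrangements cannot be told apart.

Compound 4, `CCN(CC)CCNc1nc(-c2ccc(NC(=O)Nc3ccccc3Cl)cc2)nc2ccsc12`, has not yet been measured in this assay. It stands to compound 2 as compound 3 stands to compound 1: 2-chlorophenyl in place of 4-chlorophenyl on an amide-type nitrogen. The place of the change is the same in both pairs, so this is the same change on a second core. Compound 4 is expected to sit close to compound 2, with an estimated step of a 1.3-fold higher number from compound 2 to compound 4 (0.11 log units; within the scatter), because the corresponding step on the other core, a 1.3-fold higher number from compound 1 to compound 3 (0.10 log units; within the scatter), stayed within the scatter. The only support for this is one pair of compounds, so the expectation is loose. Compound 4 is therefore estimated at 480 nM, between 200 nM and 1150 nM.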

Compound 4, half-maximal inhibitory concentration: 750 nM
Estimate against measurement, compound 4: 1.6-fold (0.19 log units) below; measured number inside the range.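

In this assay, placing 2-chlorophenyl instead of 4-chlorophenyl on the amide-type nitrogen of the second core gives a 2.0-fold higher number from compound 2 to compound 4 (0.31 log units; beyond the scatter), a modest step. Set beside the earlier step, it does not differ from it by more than the scatter of two such steps allows, so the two cores give no sign that this change behaves differently from one to the other: the same change on two cores in this assay, a 1.3-fold higher number (0.10 log units; within the scatter) from compound 1 to compound 3 and a 2.0-fold higher number (0.31 log units; beyond the scatter) from compound 2 to compound 4, 1.6-fold (0.20 log units) apart, within the scatter of two such steps. Among the compounds shown here, this agreement rests on only two pairs, one step lying within the scatter and the other beyond it, so it neither fixes a size for the step nor shows that the change would carry over in the same way to any further core, and it says nothing about why the step has the size it has.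

The compounds shown leave open how other groups on the amide-type nitrogen would read in this assay, such as an unsubstituted phenyl or a methoxyphenyl. They also leave open whether the same step would hold if a morpholine or a longer chain replaced the diethylaminoethyl chain shared by all four compounds.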